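Trimming the aryl amide down to a bare amide

A few compounds are considered here, and "the series" means these few. Any claim that something is new, unique, unknown or untested is made for them only; others in the source may bear on it.

Measured compounds:
compound 1 `Cc1ccc(C)c(NC(=O)CSc2nnc(-c3ccoc3C)n2Cc2ccco2)c1`: > 15800 nM
compound 2 `Cc1cccc(NC(=O)CSc2nnc(-c3ccoc3C)n2Cc2ccco2)c1`: 2510 nM
compound 3 `CC(=O)c1cccc(NC(=O)CSc2nnc(-c3ccoc3C)n2Cc2ccco2)c1`: 3160 nM

In a functional assay on CHO cells for antagonist activity at Orexin/Hypocretin receptor type 1 (Homo sapiens), read by FLIPR and calcium flux (on this read-out lower numbers stand for stronger inhibition and higher numbers for weaker inhibition), compound 1 reaches only a limit, > 15800 nM, so no number is known for it. Compound 2 gives 2510 nM and compound 3 gives 3160 nM; these two sit within the scatter of each other, and compound 3 holds the highest of the two plain numbers. The two steps that touch the aryl group are an at least 6.2-fold lower number from compound 1 to compound 2 (0.79 log units; beyond the scatter) and an at least 5.0-fold lower number from compound 1 to compound 3 (0.69 log units; beyond the scatter), both moving away from the limit at which compound 1 sits (the limit of > 15800 nM in this assay, at which 1 of the 3 values shown sits). The step of a 1.3-fold higher number from compound 2 to compound 3 (0.10 log units; within the scatter) stays within the scatter.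

Compound 4 `Cc1occc1-c1nnc(SCC(N)=O)n1Cc1ccco1` is the unmeasured compound. It differs from compound 3 by hydrogen in place of 3-acetylphenyl on an amide-type nitrogen. Within the data shown here, none of the measured steps removes the aryl group altogether; they only change what sits on it, so there is no direct precedent. Since the measured compounds are weak already, compound 4 is expected to move toward the limit, an estimated step of a 6.3-fold higher number from compound 3 to compound 4 (0.80 log units; beyond the scatter) in this assay. The estimate for compound 4 is 20000 nM, within a range from 6000 nM to 70000 nM, most likely reported only as a limit.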

Compound 4, inhibition constant: > 15800 nM
Compound 4 ended at the assay's limit; the forecaster's own chance of this, stated with the estimate: 70%; the middle value does not contradict the limit.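

Up to this point, only the groups on the aromatic ring had changed, while the ring itself stayed on the amide nitrogen. In this assay, replacing the whole aryl group with hydrogen to leave a bare amide gives an at least 5.0-fold higher number from compound 3 to compound 4 (0.69 log units; beyond the scatter), and the same kind of change gives an at least 6.2-fold higher number from compound 2 to compound 4 (0.79 log units; beyond the scatter). Compound 4 gives > 15800 nM, which is a limit of the assay and not a number. Among these compounds a plain number appears only with an aryl group on that nitrogen, but having one is not enough, as compound 1 with its 2,5-dimethylphenyl group goes against any such simple rule, and the step between compound 1 and compound 4 cannot be read: the limit of > 15800 nM in this assay, at which 2 of the 4 values shown sit.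

From the compounds shown here alone, it remains open whether a small group such as methyl, or a saturated ring such as cyclohexyl, on the amide nitrogen would bring back a plain number, or whether an aromatic ring is needed there. Going by these compounds, the true strength of compound 4 also remains unknown, so these results cannot show how much activity the bare amide keeps, if any.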